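A larger ring on a series without a reading

The compounds below may be only part of what the source reports. "The series", "measured", "known", "first", "only" and "open" are said of these compounds alone.

Compound 1 `CNc1ncnc2c1c(-c1cc3ccccc3o1)cn2[C@@H]1O[C@H](CO)[C@@H](O)[C@H]1O`: > 20000 nM
Compound 2 `CN(C)c1ncnc2c1c(-c1cc3ccccc3o1)cn2[C@@H]1O[C@H](CO)[C@@H](O)[C@H]1O`: > 20000 nM
Compound 3 `Cc1ncnc2c1c(-c1ccoc1)cn2[C@@H]1O[C@H](CO)[C@@H](O)[C@H]1O`: > 20000 nM

All three results come from a functional assay on HCT-116 cells (Homo sapiens), read by MTT assay, with a stated time of 72 h (a lower number here means a stronger inhibitor, a higher number a weaker inhibitor), and each is a limit of the test, not a true number. Among the measured compounds shown here, the series so far sits at one mark: the limit of > 20000 nM in this assay, at which 3 of the 3 values shown sit. Compound 3 therefore offers only a limit as a starting point, with its reading of > 20000 nM.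

Compound 4 `Cc1ncnc2c1c(-c1cc3ccccc3o1)cn2[C@@H]1O[C@H](CO)[C@@H](O)[C@H]1O` differs from compound 3 in one group: 1-benzofuran-2-yl in place of furan-3-yl on an aromatic carbon. The new group, 1-benzofuran-2-yl, is already present in two measured compounds. Compound 1 carries it and gives > 20000 nM, which is a limit. Compound 2 also carries it and gives > 20000 nM, again a limit.

For the measured compounds named here, the only measured step, a step that the two limits leave unreadable from compound 1 to compound 2, has no readable size, so it offers no guide to how large a change might be. With no true number in the series, no direction can be read from these data, and no step beyond the usual scatter is expected in this assay. The expected step is a number no higher from compound 3 to compound 4 (the limit leaves the size open). For compound 4 the estimated value is 20000 nM, with an expected range of 8000 nM to 40000 nM, and a further limit is the likeliest outcome.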

Compound 4, half-maximal inhibitory concentration: > 20000 nM
Compound 4 was reported as a limit; the forecaster's own chance of this, stated with the estimate: 75%; the middle value sits exactly at the limit.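

In this assay compound 4 gives > 20000 nM, which is a limit, so its steps from compound 1, compound 2 and compound 3 cannot be read. The series stays at a single mark: the limit of > 20000 nM in this assay, at which 4 of the 4 values shown sit. The compounds shown leave open whether 1-benzofuran-2-yl in place of furan-3-yl changes the true potency at all.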